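Cyano to methoxy on the amide aryl group

The compounds below may be only part of what the source reports. "The series", "measured", "known", "first", "only" and "open" are said of these compounds alone.

Measured in a functional assay on HepG2 cells (Homo sapiens) for antiproliferative activity, read by MTT assay, with a stated time of 24 h; a higher number here means a weaker inhibitor, a lower number a stronger inhibitor:
- compound 1 `COC(=O)c1scc(-c2ccc(NC(=O)c3cccc(I)c3)cc2)c1OC` gives 16500 nM
- compound 2 `COC(=O)c1scc(-c2ccc(NC(=O)c3ccc(C#N)nc3)cc2)c1OC` gives 22500 nM

In this assay, for the measured compounds named here, compound 2 stands level with compound 1, the only other measured compound, as their gap lies within the scatter: a 1.4-fold higher number from compound 1 to compound 2 (0.13 log units; within the scatter). That step replaced 3-iodophenyl with 6-cyanopyridin-3-yl on a carbonyl carbon. Compound 3 `COC(=O)c1scc(-c2ccc(NC(=O)c3ccc(OC)nc3)cc2)c1OC` keeps the shared core and carries methoxy in place of cyano on an aromatic carbon, next to the ring nitrogen and para to a large group (methoxy in place of cyano on an aromatic carbon). Going by the values given here, no swap of these two groups has been measured, so the step from compound 1 is the only guide. As that larger replacement stayed within the scatter, no step beyond the scatter is expected in this assay, and no direction is favoured. The expected step is a 1.1-fold lower number from compound 2 to compound 3 (0.05 log units; within the scatter). Compound 3 is estimated at 20000 nM, within an expected range of 9000 nM to 45000 nM.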

Compound 3, half-maximal inhibitory concentration: > 50000 nM
Compound 3 was reported as a limit; the forecaster's own chance of this, stated with the estimate: 10%; middle value at least 2.5-fold (0.39 log units) from the limit.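

In this assay compound 3 is reported only as a limit, not as a number: the limit of > 50000 nM in this assay, at which 1 of the 3 values shown sits.

The group on this aromatic carbon matters to the read-out, a point the earlier pair could not show, since the exchange of cyano for methoxy gives an at least 2.2-fold higher number from compound 2 to compound 3 (0.34 log units; beyond the scatter). The whole aryl group also counts: 6-methoxypyridin-3-yl in place of 3-iodophenyl gives an at least 3.0-fold higher number from compound 1 to compound 3 (0.48 log units; beyond the scatter), whereas 6-cyanopyridin-3-yl in place of 3-iodophenyl gave a 1.4-fold higher number from compound 1 to compound 2 (0.13 log units; within the scatter).

On these data alone, both new steps are lower bounds, so their true size stays open. Also open is whether an amine, a hydroxyl group or a longer chain such as ethoxy at this position would read like compound 2 or like compound 3, and the compounds shown give no cause for the step.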